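Second Chloro Group on a Benzyl-Substituted Fused Core

The source may hold more compounds than are shown below. What is called first, only, known or untested is meant among the compounds shown, and "the series" means these compounds.

Of the compounds shown here, three have so far been tested in a functional assay on EKVX cells (Homo sapiens) for cytotoxicity, read by sulforhodamine B assay, with a stated time of 48 h; on this read-out lower numbers stand for higher toxicity in this test and higher numbers for lower toxicity in this test. Compound 1 `ClCc1ccccc1Cn1cnc2c(Cl)nc(Cl)nc21` gives 5880 nM. Compound 2 `ClCc1ccccc1Cn1cnc2c(Cl)ncnc21` carries a hydrogen where compound 1 carries a chloro group; in this assay compound 2 gives 37200 nM. The change from compound 2 to compound 1 is chloro in place of hydrogen on an aromatic carbon, and it made a step of a 6.3-fold lower number from compound 2 to compound 1 (0.80 log units; beyond the scatter), a clear gain in toxicity in this test.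

Compound 3 `ClCc1cccc(Cn2cnc3c(Cl)ncnc32)c1` is built from the same atoms as compound 2, joined differently; the difference between the two cores is not broken down here. In this assay compound 3 gives 63100 nM, a number that lies within the usual scatter of the number for compound 2, so the two cannot be told apart on this evidence.

Compound 4 `ClCc1cccc(Cn2cnc3c(Cl)nc(Cl)nc32)c1` has not yet been measured. It differs from compound 3 by chloro in place of hydrogen on an aromatic carbon. The place of this change is described in exactly the same words as the place of the change from compound 2 to compound 1, so it is the same change applied to the other core. Among the compounds with values here, the step from compound 3 to compound 4 is therefore expected to be a 6.3-fold lower number from compound 3 to compound 4 (0.80 log units; beyond the scatter), resting on the single earlier example a 6.3-fold lower number from compound 2 to compound 1 (0.80 log units; beyond the scatter). Within the data shown here, with only one such example, and with the cores of compound 2 and compound 3 differing in an unbroken-down way, the expectation is held loosely. Compound 4 is estimated to give 10000 nM, expected to fall between 4000 nM and 28000 nM.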

Compound 4, concentration lethal to 50% of the cells: 6450 nM
Estimate against measurement, compound 4: 1.6-fold (0.19 log units) above; the range from low to high includes it.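

In this assay, putting a chloro group in place of hydrogen on the aromatic carbon between two ring nitrogen atoms gave a 9.8-fold lower number from compound 3 to compound 4 (0.99 log units; beyond the scatter), so the compound with the added chloro group again showed the higher toxicity in this test. Set beside the earlier example, the step kept both its direction and, within the scatter, its size when the change moved to the other core: the same change on two cores in this assay, a 6.3-fold lower number (0.80 log units; beyond the scatter) from compound 2 to compound 1 and a 9.8-fold lower number (0.99 log units; beyond the scatter) from compound 3 to compound 4, 1.5-fold (0.19 log units) apart, within the scatter of two such steps This shows that, for these two closely related cores, the effect of the change carried over, but two pairs cannot establish a general rule, and the numbers do not explain why the chloro group lowers the reading or predict what it would do on a third core or in another cell line.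

Going by these compounds, it remains open whether the gain belongs to chloro itself or whether another group on the same aromatic carbon, such as an amine or a methoxy group, would shift the reading in the same way. On these data alone, it is also open how much the chloromethyl group contributes in either core, a question that a compound carrying a plain methyl group there could address.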